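A few compounds are considered here, and "the series" means these few. Any claim that something is new, unique, unknown or untested is made for them only; others in the source may bear on it.

In a functional assay on MDA-MB-231 cells (Homo sapiens) for antiproliferative activity, read by MTT assay, with a stated time of 24 h (a higher number here means a weaker inhibitor, a lower number a stronger inhibitor), compound 1 `CCCCc1oc2ccccc2c1C(=O)c1ccc(OCC(=O)NCc2ccccc2)cc1` gives > 50000 nM, which is a limit. Compound 2 `CCCCc1oc2ccccc2c1C(=O)c1ccc(OCC(=O)N[C@@H](C)c2ccccc2)cc1` gives > 50000 nM, also a limit, so it has no numerical position in the series. Both measurements sit at the same ceiling: the limit of > 50000 nM in this assay, at which 2 of the 2 values shown sit. Compound 3 `CCCCc1oc2ccccc2c1C(=O)c1ccc(OCC(=O)N[C@H](C)c2ccccc2)cc1` is related to compound 2 by the two compounds have the same atoms and bonds and differ only in configuration as drawn: 1 of 1 stereo elements differ; a stereocentre at a saturated chain carbon is drawn S in compound 2 and R in compound 3. Among the compounds with values here, the one measured step that bears on this change is a step that the two limits leave unreadable from compound 1 to compound 2, and it supplies no size to carry over. No step beyond the scatter is therefore expected in this assay, although activity appearing in compound 3 cannot be excluded. The expected change is a number no higher from compound 2 to compound 3 (the limit leaves the size open). Compound 3 will most likely be reported only as a limit too. For compound 3 the estimated value is 50000 nM, with an expected range of 25000 nM to 100000 nM.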

Compound 3, half-maximal inhibitory concentration: 39000 nM
For compound 3 the middle estimate is 1.3-fold (0.11 log units) above the measured one; measured number inside the range.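

In this assay, within the data shown here, compound 3 gives 39000 nM, the first number rather than a limit, so this carbon now has one readable value. The steps can be read only as floors, an at least 1.2-fold lower number from compound 2 to compound 3 (0.10 log units; that floor lies within the scatter) and an at least 1.2-fold lower number from compound 1 to compound 3 (0.10 log units; that floor lies within the scatter), and neither is shown to exceed the scatter. Any real difference between compound 2 and compound 3 would rest on the one stereocentre at the saturated chain carbon, with no other structural change involved: the fact that compounds 2 and 3 differ only in the configuration as drawn

From the compounds shown here alone, the true size of both steps stays open, and most of the values give no position: the limit of > 50000 nM in this assay, at which 2 of the 3 values shown sit. Also open is whether an ethyl group in place of the methyl, in the configuration of compound 3, would give a readable number at all.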